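The source may report more compounds than this note shows. Statements on the series, on what has been measured and on what is new or still open speak of the compounds shown alone.

Compound 1 `CC(C)Cc1ccc2c(NCCCNCc3ccco3)ccnc2c1` was examined in a physicochemical assay for solubility, with a stated time of 18 h, at pH 7.4 (a higher number here means a more soluble compound, a lower number a less soluble compound), where compound 1 gives 4200 nM. Compound 2 `COc1ccc(F)cc1CNCCCNc1ccnc2cc(Cc3cc(C)cc(C)c3)ccc12` gives 4200 nM in this assay, and compound 3 `COc1ccc(F)cc1CNCCCNc1ccnc2cc(C3CCCCC3)ccc12` gives 4200 nM, so compound 1 stands level with compounds 2 and 3 within the scatter. Going by the values given here, the only measured step that exchanges a group on an aromatic carbon of the shared core, no change at the digits printed from compound 2 to compound 3 (within the scatter), left the reading unchanged. Compound 4 `Fc1ccc(Oc2ccc3c(NCCCNCc4ccco4)ccnc3c2)cc1` has not yet been measured. It differs from compound 1 in one place: 4-fluorophenoxy in place of isobutyl on an aromatic carbon. Because the step of no change at the digits printed from compound 2 to compound 3 (within the scatter) was flat, an exchange of a group on an aromatic carbon of the shared core gives no sign of a move in this assay, although the 4-fluorophenoxy group entering compound 4 is not one seen among the measured compounds, so the uncertainty is wider than that single step suggests. The expectation for compound 4 is therefore a step of a 1.4-fold lower number from compound 1 to compound 4 (0.15 log units; within the scatter), no larger than the scatter. Compound 4 is estimated to give 3000 nM in this assay, within a range from 1000 nM to 9000 nM.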

Compound 4, solubility: 14500 nM
Beside the measured number, compound 4's estimate is 4.8-fold (0.68 log units) below it; measured number above the stated range.
By their numbers in this assay, from the lowest: compounds 1, 2 and 3 (each within the scatter of the next); then compound 4.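

In this assay the exchange of isobutyl for 4-fluorophenoxy gives a 3.5-fold higher number from compound 1 to compound 4 (0.54 log units; beyond the scatter) and so shows that this aromatic carbon is not a place where every exchange leaves the reading flat, as no change at the digits printed from compound 2 to compound 3 (within the scatter) alone might have suggested. The entering group has 8 heavy atoms against 4 for isobutyl, yet the number rose rather than fell, though the step is only modest. Nothing offered here gives a measured property that accounts for this rise.

The compounds shown leave open which part of the new group goes with the step: the aromatic ring, the ether oxygen or the fluorine, as a plain phenoxy or a 4-chlorophenoxy group would begin to tell. They also leave open whether a morpholine at this carbon would move the reading at all, or whether the same exchange would hold with the side chain of compounds 2 and 3.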